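The compounds below may be only part of what the source reports. "The series", "measured", "known", "first", "only" and "open" are said of these compounds alone.

Compound 1 `COc1ccc([C@@H]2CC(=O)c3c(O)cc(OCc4cn(Cc5ccccc5C#N)nn4)cc3O2)cc1O` and compound 2 `C#CCOc1cc(O)c2c(c1)O[C@H](c1ccc(OC)c(O)c1)C/C2=N\O` share a core and have both been measured in a functional assay on RAW264.7 cells (Mus musculus) for inhibition, read by Griess assay, with stated times of 2 h and 24 h; a higher number here means a weaker inhibitor, a lower number a stronger inhibitor. In this assay compound 1 gives 14600 nM, and in this assay compound 2 gives 19100 nM; the two values lie within the scatter of each other, so compound 1 holds the lower number of the two without any real separation between them. Compound 3 `CCCn1cc(COc2cc(O)c3c(c2)O[C@H](c2ccc(OC)c(O)c2)CC3=O)nn1` has not yet been measured in this assay. It differs from compound 1 in one place: ethyl in place of 2-cyanophenyl on a saturated chain carbon bound to an aromatic nitrogen. For the measured compounds named here, no measured pair shows this change, so the numbers in hand give no guide to its effect, and nothing in them points to a move in either direction. The expected step is a 1.2-fold higher number from compound 1 to compound 3 (0.09 log units; within the scatter), none beyond the scatter. For compound 3 the estimate in this assay is 18000 nM, with a range from 7000 nM to 45000 nM.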

Compound 3, half-maximal inhibitory concentration: 9670 nM
Estimate against measurement, compound 3: 1.9-fold (0.27 log units) above; measured number inside the range.
By their numbers in this assay, from the lowest: compounds 3, 1 and 2 (each within the scatter of the next).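

For the compounds shown here, compound 3 gives the first measured pair at this position: in this assay there is a 1.5-fold lower number from compound 1 to compound 3 (0.18 log units; within the scatter). Propyl and 2-cyanobenzyl therefore cannot be told apart here, and a compound without the six-membered aromatic ring and the nitrile keeps a value within the scatter of compound 1, so in this pair neither feature is needed to hold the number at this level. No measurement at hand bears on why the two groups read alike.

This single step does not show whether any group on a saturated chain carbon bound to an aromatic nitrogen can move the number beyond the scatter. From the compounds shown here alone, it remains open how a plain benzyl, a longer chain such as hexyl, or a chain ending in an amine or a carboxylic acid would read in this assay.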